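A few compounds are considered here, and "the series" means these few. Any claim that something is new, unique, unknown or untested is made for them only; others in the source may bear on it.

Compounds and values in an ADME assay on HEL cells (Homo sapiens) for cytotoxicity; on this read-out lower numbers stand for higher toxicity in this test and higher numbers for lower toxicity in this test:

- compound 1 `COc1cc(NC(C)CCCNC(=O)NC(c2ccccc2)c2ccccc2)c2ncccc2c1` — limit > 100000 nM
- compound 2 `COc1cc(NC(C)CCCNC(=O)NC2CCCCC2)c2ncccc2c1` — 94000 nM
- compound 3 `COc1cc(NC(C)CCCNC(=O)N(C2CCCCC2)C2CCCCC2)c2ncccc2c1` — 27000 nM
- compound 4 `COc1cc(NC(C)CCCNC(=O)n2nnc3ccccc32)c2ncccc2c1` — not yet measured

Compound 1 reaches only the limit of the assay, (the limit of > 100000 nM in this assay, at which 1 of the 3 values shown sits). Among the two numbers shown, compound 2 holds the highest one; the nearest is compound 3, reached by a 3.5-fold lower number from compound 2 to compound 3 (0.54 log units; beyond the scatter), a modest step coming from cyclohexyl in place of hydrogen on an amide-type nitrogen.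

Compound 4 differs from compound 2 by a group of 9 heavy atoms (6 carbon, 3 nitrogen; one five-membered aromatic ring with 3 hetero atoms, one six-membered aromatic ring of carbon only) in place of a group of 7 heavy atoms (6 carbon, 1 nitrogen; one six-membered non-aromatic ring of carbon only), on a carbonyl carbon. Among the compounds with values here, this is a different kind of change from the one between compound 2 and compound 3: there a second cyclohexyl was added on the nitrogen, here the cyclohexylamino is exchanged for an aromatic bicyclic group on the carbonyl carbon. Within the data shown here, the only measured step in this assay is thus an imperfect guide. Since compound 2 gives 94000 nM and added ring bulk in compound 3 lowered the number modestly, the expectation for compound 4 is a small change, if any, towards a lower number, of about a 1.6-fold lower number from compound 2 to compound 4 (0.19 log units; within the scatter). The estimate for compound 4 is therefore 60000 nM, with a range from 20000 nM to 200000 nM, which leaves open that the assay again reports only a limit.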

Compound 4, half-maximal cytotoxic concentration: 72000 nM
Estimate against measurement, compound 4: 1.2-fold (0.08 log units) below, within the range that was stated.
By their numbers in this assay, from the lowest: compound 3; then compounds 4 and 2 (each within the scatter of the next). At a limit, above all of these: compound 1.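

In this assay, the carbonyl carbon takes the aromatic bicyclic group in place of cyclohexylamino with no readable shift: a 1.3-fold lower number from compound 2 to compound 4 (0.12 log units; within the scatter). Within the data shown here, this exchange swaps a non-aromatic carbon ring for two aromatic rings and replaces the hydrogen-bond donor of the cyclohexylamino with hydrogen-bond acceptors, so neither that donor nor that non-aromatic ring is needed to hold the read-out at the level of compound 2, whereas the only earlier step, the added cyclohexyl on the amide-type nitrogen, gave a 3.5-fold lower number from compound 2 to compound 3 (0.54 log units; beyond the scatter). Nothing at hand gives a measured property that would explain why this exchange leaves the number in place.

Still open is whether a charged group on the same carbonyl carbon, such as a primary amine or a carboxylic acid in place of cyclohexylamino, would move the number beyond the scatter, given that the groups shown here carry no net charge. Also open, from the compounds shown here alone, is whether a longer chain between the urea-type carbonyl and the shared core would change the read-out for the cyclohexylamino and bicyclic groups alike.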